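Trifluoromethyl to ethoxy: an expected loss of potency

This account rests on a few compounds, and the source may have more. Where it says the series, first, only, none or still open, it means among the compounds named here.

Of the compounds shown here, three built on one shared core have been tested in a functional assay on MDA-MB-231 cells (Homo sapiens) for cytotoxicity, read by MTT assay, with a stated time of 72 h; on this read-out higher numbers stand for weaker inhibition and lower numbers for stronger inhibition. Compound 1 `CCOc1ccccc1Nc1nc(SCc2ccc(C(F)(F)F)cc2)nc2ccccc12` carries a 2-ethoxyphenyl group on a nitrogen on an aromatic ring; in this assay compound 1 gives > 50000 nM, which is a limit of the assay rather than a number (the limit of > 50000 nM in this assay, at which 1 of the 3 values shown sits). Compound 2 `O=[N+]([O-])c1ccc(Nc2nc(SCc3ccc(C(F)(F)F)cc3)nc3ccccc23)cc1` gives 8670 nM. Compound 3 `FC(F)(F)c1ccc(CSc2nc(Nc3ccc(C(F)(F)F)cc3)c3ccccc3n2)cc1` gives 5460 nM, which stands lowest among the numbers shown, although the step of a 1.6-fold lower number from compound 2 to compound 3 (0.20 log units; within the scatter) is within the scatter. By contrast, the steps of an at least 5.7-fold lower number from compound 1 to compound 2 (0.76 log units; beyond the scatter) and an at least 9.1-fold lower number from compound 1 to compound 3 (0.96 log units; beyond the scatter) both ran beyond the scatter.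

Compound 4 `CCOc1ccc(Nc2nc(SCc3ccc(C(F)(F)F)cc3)nc3ccccc23)cc1` differs from compound 3 by ethoxy in place of trifluoromethyl on an aromatic carbon. For the measured compounds named here, no measured step makes exactly this swap. The nearest is an at least 9.1-fold lower number from compound 1 to compound 3 (0.96 log units; beyond the scatter), where a ring bearing ethoxy was exchanged for one bearing trifluoromethyl and the number fell sharply, though there the ethoxy sat as 2-ethoxyphenyl. Running that exchange backwards, compound 4 is expected to give a higher number in this assay, by roughly a 3.7-fold higher number from compound 3 to compound 4 (0.56 log units; beyond the scatter). The estimate for compound 4 is 20000 nM, expected to lie between 6000 nM and 60000 nM.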

Compound 4, half-maximal inhibitory concentration: 23000 nM
Estimate against measurement, compound 4: 1.2-fold (0.06 log units) below, within the range that was stated.
By their numbers in this assay, from the lowest: compounds 3 and 2 (each within the scatter of the next); then compound 4. At a limit, above all of these: compound 1.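

In this assay, ethoxy can now be read directly at the place para to a large group, against the two groups that gave the lowest numbers: a 4.2-fold higher number from compound 3 to compound 4 (0.62 log units; beyond the scatter) and a 2.7-fold higher number from compound 2 to compound 4 (0.42 log units; beyond the scatter). The earlier step from the 2-ethoxyphenyl compound changed both the group and its place, whereas keeping ethoxy and changing only its place, as 4-ethoxyphenyl in place of 2-ethoxyphenyl, gives an at least 2.1-fold lower number from compound 1 to compound 4 (0.33 log units; beyond the scatter), so place alone moves the number as well. The size of that last step stays open-ended, since compound 1 stands at a limit and not at a number: the limit of > 50000 nM in this assay, at which 1 of the 4 values shown sits.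

As far as these compounds go, how an amine, a carboxylic acid or a longer chain such as butoxy would read at this place remains open. So does whether trifluoromethyl or nitro would respond to a change of place as ethoxy does.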